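Propylsulfanyl in place of propyl: expectation for compound 4

The source may report more compounds than this note shows. Statements on the series, on what has been measured and on what is new or still open speak of the compounds shown alone.

Measured compounds:
- compound 1, `Cc1c(C(=O)N=C(N)N)cc(S(C)(=O)=O)c(Cl)c1[N+](=O)[O-]`; in a functional assay for inhibition of sodium/hydrogen exchanger (Oryctolagus cuniculus) (a higher number here means a weaker inhibitor, a lower number a stronger inhibitor), compound 1 gives 44 nM
- compound 2, `CCCc1cc(C)c(C(=O)N=C(N)N)cc1S(C)(=O)=O`; in this assay compound 2 gives 5.7 nM
- compound 3, `Cc1c(C(=O)N=C(N)N)cc(S(C)(=O)=O)c(C)c1C`; in this assay compound 3 gives 55 nM

Compound 2 stands at the lowest number of the three, and both other compounds lie beyond the scatter from it: compound 1 sits at a higher number, compound 3 higher still. No two of the measured compounds differ in only one place, so no step size can be read from the measured set.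

Compound 4, `CCCSc1cc(C)c(C(=O)N=C(N)N)cc1S(C)(=O)=O`, differs from compound 2 in a single place: propylsulfanyl in place of propyl on an aromatic carbon. The measured set holds nothing that isolates this exchange, so the direction is not anchored by any measured pair. The step is expected to be small, a 1.4-fold higher number from compound 2 to compound 4 (0.15 log units; within the scatter), with a slight lean toward a higher number, but not clearly beyond the scatter. Compound 4 is therefore expected to give about 8 nM in this assay, with a range from 2.5 nM to 25 nM.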

Compound 4, half-maximal inhibitory concentration: 6.8 nM
Compound 4: the middle estimate sits 1.2-fold (0.07 log units) above what was measured; the measured number falls inside the stated range.
By their numbers in this assay, from the lowest: compounds 2 and 4 (each within the scatter of the next); then compounds 1 and 3 (each within the scatter of the next).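

In this assay, propylsulfanyl in place of propyl on an aromatic carbon gives a 1.2-fold higher number from compound 2 to compound 4 (0.08 log units; within the scatter) and so stays within the scatter. For the compounds shown here, this is the first single-place comparison, and it shows that this position, ortho to a methylsulfonyl group, accepts a chain carrying a sulfur atom without a step beyond the scatter. Nothing on hand accounts for the closeness of these two numbers.

Open, from the compounds shown here alone, is whether other groups at this carbon, such as an amine, a carboxylic acid or a longer alkyl chain, would also stay within the scatter. Going by these compounds alone, only one pair carries this exchange, so whether it would behave alike with the other groups around the core of compound 1 or compound 3 also remains open.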